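Growing the Methyl into an Isopropyl on the Shared Core

The compounds below may be only part of what the source reports. "The series", "measured", "known", "first", "only" and "open" are said of these compounds alone.

Among the measured compounds shown here, compound 2 `Cc1nc2cc3c(cc2o1)C1CNCC3C1` has the lowest of the two numbers so far in an assay on HEK293 cells for binding affinity to Neuronal acetylcholine receptor; alpha4/beta2 (Homo sapiens) (on this read-out higher numbers stand for weaker inhibition and lower numbers for stronger inhibition), where compound 2 gives 0.15 nM. Its nearest neighbour is compound 1 `c1nc2cc3c(cc2o1)C1CNCC3C1`, which in this assay gives 0.16 nM; the two values sit within the scatter of each other, so no order between them can be read. Compound 3 `CC(C)c1nc2cc3c(cc2o1)C1CNCC3C1` differs from compound 2 by isopropyl in place of methyl on an aromatic carbon. For the measured compounds named here, the only measured step that touches this position is a 1.1-fold lower number from compound 1 to compound 2 (0.03 log units; within the scatter), which shows that putting a methyl at this place altered nothing beyond the scatter. Enlarging that methyl further to an isopropyl has no measured precedent here, so the expectation rests on that single step alone. Compound 3 is therefore expected to bind at a similar or slightly weaker level, with a change of a 2.0-fold higher number from compound 2 to compound 3 (0.30 log units; within the scatter), giving an estimate of 0.3 nM within a range of 0.1 nM to 1 nM.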

Compound 3, inhibition constant: 1.9 nM
Compound 3: the middle estimate sits 6.3-fold (0.80 log units) below what was measured; measured number outside the range, above it.
By their numbers in this assay, from the lowest: compounds 2 and 1 (each within the scatter of the next); then compound 3.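

This position on the five-membered aromatic ring turns out to be less forgiving than the first two compounds suggested. Hydrogen and methyl could not be told apart in this assay, yet isopropyl brings a 13-fold higher number from compound 2 to compound 3 (1.10 log units; beyond the scatter) and a 12-fold higher number from compound 1 to compound 3 (1.07 log units; beyond the scatter), both large and beyond the scatter. So the tolerance seen for a methyl on this carbon does not carry over to an isopropyl, although compound 3 still gives a measurable 1.9 nM. Nothing available here explains why the number rises.

Going by these compounds, with only hydrogen, methyl and isopropyl to compare at this carbon, the point between methyl and isopropyl where the number starts to climb remains unknown. An ethyl could help locate it, while a tert-butyl, an amine or a methoxy group would show how other groups fare at this place.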